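A few compounds are considered here, and "the series" means these few. Any claim that something is new, unique, unknown or untested is made for them only; others in the source may bear on it.

Compound 1 `O=C(CCl)Nc1ccc(SCC(=O)Nc2ccc(Cl)cn2)cc1` carries a chloromethyl group on its carbonyl carbon and a 5-chloropyridin-2-yl ring on an amide-type nitrogen. In a functional assay on A875 cells (Homo sapiens) for antiproliferative activity, read by MTT assay, with a stated time of 48 h (a lower number here means a stronger inhibitor, a higher number a weaker inhibitor), compound 1 gives 98 nM. Compound 2 `O=C(CCl)Nc1ccc(SCC(=O)Nc2cc(Cl)ccn2)cc1` differs from it in one place, (4-chloropyridin-2-yl in place of 5-chloropyridin-2-yl on an amide-type nitrogen), and in this assay compound 2 gives 850 nM, which is an 8.7-fold higher number from compound 1 to compound 2 (0.94 log units; beyond the scatter). Compound 3 `CC(C)(C)C(=O)Nc1ccc(SCC(=O)Nc2ccc(Cl)cn2)cc1` keeps the ring of compound 1 but changes the group on the carbonyl carbon, (tert-butyl in place of chloromethyl on a carbonyl carbon). In this assay compound 3 reaches only a limit, > 80000 nM, and not a number. That step is therefore an at least 810-fold higher number from compound 1 to compound 3 (2.91 log units; beyond the scatter), with compound 3 sitting at the limit of > 80000 nM in this assay, at which 1 of the 3 values shown sits. Compound 4 `CC(C)(C)C(=O)Nc1ccc(SCC(=O)Nc2cc(Cl)ccn2)cc1` has not yet been measured in this assay. It stands to compound 3 as compound 2 stands to compound 1: the same change, (4-chloropyridin-2-yl in place of 5-chloropyridin-2-yl on an amide-type nitrogen), at the same place, an amide-type nitrogen whose other neighbour is a carbonyl carbon. The earlier change raised the number, an 8.7-fold higher number from compound 1 to compound 2 (0.94 log units; beyond the scatter), so from compound 3 to compound 4 the number is expected to rise by a similar amount. The expected step from compound 3 is a step that the limit leaves unreadable from compound 3 to compound 4. Compound 4 is estimated at 400000 nM, most likely again only a limit.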

Compound 4, half-maximal inhibitory concentration: > 80000 nM
Compound 4 ended at the assay's limit; the forecaster's own chance of this, stated with the estimate: 90%; the middle value does not contradict the limit.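

In this assay, tert-butyl in place of chloromethyl on the carbonyl carbon again brings a large rise, an at least 94-fold higher number from compound 2 to compound 4 (1.97 log units; beyond the scatter), and this step rests on a limit for compound 4, not on a number. The change therefore carries over to the second core in the same direction, but its size on each core remains only a minimum: the same change on two cores in this assay, an at least 810-fold higher number (2.91 log units; beyond the scatter) from compound 1 to compound 3 and an at least 94-fold higher number (1.97 log units; beyond the scatter) from compound 2 to compound 4; the limit leaves it open whether they differ. From the compounds shown here alone, the ring change, 4-chloropyridin-2-yl in place of 5-chloropyridin-2-yl, cannot be read between the two tert-butyl compounds, so whether it carries over to that core remains unknown: the limit of > 80000 nM in this assay, at which 2 of the 4 values shown sit.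

Going by these compounds, it remains open whether a bromomethyl or a plain methyl group on the carbonyl carbon would keep the number close to that of compound 1, 98 nM. Also open, on these data alone, is how a fluorine or a methoxy group in place of the chlorine on the pyridine ring would behave with the chloromethyl group present.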